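Longer Chain on the Aromatic Oxygen: Expected Gain

The compounds below may be only part of what the source reports. "The series", "measured", "known", "first", "only" and "open" are said of these compounds alone.

Compound 3 `CC(C)Oc1cc([N+](=O)[O-])ccc1N(C)S(C)(=O)=O` is measured in an assay on SK-BR-3 cells for inhibition of Aromatase (Homo sapiens) (on this read-out higher numbers stand for weaker inhibition and lower numbers for stronger inhibition), where compound 3 gives 2810 nM. Among the three measured compounds it stands second highest: compound 1 `CC(C)Oc1cc([N+](=O)[O-])ccc1NS(C)(=O)=O` gives 5870 nM, and compound 2 `CS(=O)(=O)Nc1ccc([N+](=O)[O-])cc1OCC1CCCCC1` gives 1210 nM. Compound 4 `CCCCCCOc1cc([N+](=O)[O-])ccc1N(C)S(C)(=O)=O` differs from compound 3 in one place: hexyl in place of isopropyl on an oxygen on an aromatic ring.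

Among the measured compounds shown here, one measured step bears directly on this change. Replacing isopropyl with cyclohexylmethyl on the same oxygen gave a 4.9-fold lower number from compound 1 to compound 2 (0.69 log units; beyond the scatter), so a larger group in this place has once lowered the number. The other step, a 2.1-fold lower number from compound 1 to compound 3 (0.32 log units; beyond the scatter), concerns the sulfonamide nitrogen and is already part of compound 3, so it says nothing further about the oxygen. Hexyl is not cyclohexylmethyl, but it is likewise a larger group at the same place, so a modest downward step, beyond the scatter, is the reasonable expectation. Compound 4 is therefore expected to show a 3.0-fold lower number from compound 3 to compound 4 (0.47 log units; beyond the scatter), giving an estimated value of 950 nM, with a range from 300 nM to 2800 nM.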

Compound 4, half-maximal inhibitory concentration: 4490 nM
Estimate against measurement, compound 4: 4.7-fold (0.67 log units) below, and the stated range ends below it.
By their numbers in this assay, from the lowest: compound 2; then compounds 3, 4 and 1 (each within the scatter of the next, the first and the last beyond it).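

In this assay, lengthening the group on this oxygen from isopropyl to hexyl gives a 1.6-fold higher number from compound 3 to compound 4 (0.20 log units; within the scatter) and stays within the scatter, so a longer chain here does not by itself lower the number. A larger group on this oxygen therefore does not lower the number as a rule: cyclohexylmethyl gave a 4.9-fold lower number from compound 1 to compound 2 (0.69 log units; beyond the scatter) as a step beyond the scatter, while hexyl, which has no ring, goes against that pattern. Nothing measured here accounts for the difference between these two groups.

The two steps also start from different compounds, one with hydrogen and one with methyl on the sulfonamide nitrogen, so the role of the ring cannot be separated from that of the methyl. From the compounds shown here alone, how ethyl, benzyl or a chain ending in an amine would behave on this oxygen remains open.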